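The source may hold more compounds than are shown below. What is called first, only, known or untested is meant among the compounds shown, and "the series" means these compounds.

Of the compounds shown here, three built on one shared core have been measured in an assay on cells for agonist activity at ecdysone receptor (Bombyx mori), read by a luciferase reporter, with a stated time of 24 h; a higher number here means that more compound is needed for the effect, a lower number that less compound is needed. Compound 1 `CC(C)(C)N(NC(=O)c1ccccc1I)C(=O)c1ccccc1Cl` gives 1290 nM in this assay. Compound 2 `Cc1ccccc1C(=O)NN(C(=O)c1ccccc1Cl)C(C)(C)C` gives 72.4 nM, and compound 3 `CC(C)(C)N(NC(=O)c1ccc(Cl)cc1)C(=O)c1ccccc1Cl` gives 115 nM. On these numbers compound 3 stands second highest of the three; its nearest neighbour is compound 2, and the step of a 1.6-fold higher number from compound 2 to compound 3 (0.20 log units; within the scatter) lies within the scatter, so the two cannot be told apart. The step of an 11-fold lower number from compound 1 to compound 3 (1.05 log units; beyond the scatter) is large, as is an 18-fold lower number from compound 1 to compound 2 (1.25 log units; beyond the scatter).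

Compound 4 `Cc1ccc(C)c(C(=O)NN(C(=O)c2ccccc2Cl)C(C)(C)C)c1` has not yet been measured. It differs from compound 3 in one place: 2,5-dimethylphenyl in place of 4-chlorophenyl on a carbonyl carbon. The measured step that bears most directly on this change is a 1.6-fold higher number from compound 2 to compound 3 (0.20 log units; within the scatter), where 4-chlorophenyl stands in place of 2-methylphenyl on a carbonyl carbon and the number did not move beyond the scatter. Among the measured compounds shown here, no measured compound carries the 2,5-dimethylphenyl group, so the second methyl has no precedent in this set. Compound 4 is therefore expected to land close to compound 2 and compound 3, with a 1.6-fold lower number from compound 3 to compound 4 (0.22 log units; within the scatter) not beyond the scatter. The estimated value for compound 4 in this assay is 70 nM, within a range from 20 nM to 250 nM.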

Compound 4, half-maximal effective concentration: 1620 nM
Compound 4: the middle estimate sits 23-fold (1.36 log units) below what was measured; measured number above the stated range.
By their numbers in this assay, from the lowest: compounds 2 and 3 (each within the scatter of the next); then compounds 1 and 4 (each within the scatter of the next).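

In this assay, one added methyl is enough to change the result sharply: the step from the 2-methylphenyl group to the 2,5-dimethylphenyl group is a 22-fold higher number from compound 2 to compound 4 (1.35 log units; beyond the scatter) and is large. This group on the carbonyl carbon therefore does not accept every small addition, although replacing 2-methylphenyl with 4-chlorophenyl had left the number within the scatter. The direct comparison, a 14-fold higher number from compound 3 to compound 4 (1.15 log units; beyond the scatter), is also large, whereas a 1.3-fold higher number from compound 1 to compound 4 (0.10 log units; within the scatter) lies within the scatter, so the 2,5-dimethylphenyl and 2-iodophenyl groups cannot be told apart here, and both need far more compound than the 2-methylphenyl group does. No measured information is available to explain the effect of the second methyl.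

The compounds shown do not reveal whether this loss is specific to methyl or would also follow from another group at the same place on the ring. A methoxy group, an amine or a carboxylic acid in place of the second methyl could help separate those possibilities.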